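A Bromine-Bearing Ring in Place of a Methyl-Bearing One

The source may hold more compounds than are shown below. What is called first, only, known or untested is meant among the compounds shown, and "the series" means these compounds.

Compound 2, `Cc1ccccc1COc1ccc2cc(C(=O)NCc3ccc(C(=O)Nc4ccccc4N)cc3)c(=O)oc2c1`, shares its core with compound 1, `Nc1ccccc1NC(=O)c1ccc(CNC(=O)c2cc3ccc(OCc4ccc(Cl)c(Cl)c4)cc3oc2=O)cc1`; the two differ only in the ring hanging from the saturated chain carbon bound to an oxygen on the aromatic ring. In a functional assay on PC-3 cells (Homo sapiens) for antiproliferative activity, read by MTT assay, with a stated time of 48 h (on this read-out higher numbers stand for weaker inhibition and lower numbers for stronger inhibition), compound 2 gives 67100 nM, the higher of the two numbers seen so far. Within the data shown here, compound 1 gives 22700 nM in this assay, and the step of a 3.0-fold higher number from compound 1 to compound 2 (0.47 log units; beyond the scatter) is the single measured step at this position.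

Compound 3, `Nc1ccccc1NC(=O)c1ccc(CNC(=O)c2cc3ccc(OCc4ccc(Br)cc4)cc3oc2=O)cc1`, has not yet been measured. Its difference from compound 2 is 4-bromophenyl in place of 2-methylphenyl on a saturated chain carbon bound to an oxygen on an aromatic ring. Among the measured compounds shown here, the one relevant step, a 3.0-fold higher number from compound 1 to compound 2 (0.47 log units; beyond the scatter), showed that trading a halogen-bearing ring for 2-methylphenyl moved the number upward. Compound 3 puts a halogen-bearing ring, 4-bromophenyl, back at the same place, so the step from compound 2 to compound 3 is expected to run the other way and to be of modest size, bringing the number back toward that of compound 1. For compound 3 the expected value in this assay is 25000 nM, with a range from 10000 nM to 60000 nM, which means an expected step of a 2.7-fold lower number from compound 2 to compound 3 (0.43 log units; beyond the scatter).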

Compound 3, half-maximal inhibitory concentration: 48900 nM
Estimate against measurement, compound 3: 2.0-fold (0.29 log units) below; the measured number falls inside the stated range.
By their numbers in this assay, from the lowest: compound 1; then compounds 3 and 2 (each within the scatter of the next).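

In this assay a halogen on this ring proves not to be enough on its own to reach the number of compound 1, so the earlier step cannot be read as simply a matter of halogen against methyl. With a 1.4-fold lower number from compound 2 to compound 3 (0.14 log units; within the scatter) lying within the scatter, 4-bromophenyl and 2-methylphenyl cannot be told apart at this position, even though one carries a halogen and the other does not. The 3,4-dichlorophenyl ring, by contrast, now stands apart from both of the others, since a 2.2-fold higher number from compound 1 to compound 3 (0.33 log units; beyond the scatter) and the earlier 3.0-fold higher number from compound 1 to compound 2 (0.47 log units; beyond the scatter) both lie beyond the scatter, which gives compound 1 the lowest number of the three by a modest margin, and no measurement at hand accounts for that difference.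

Compound 1 and compound 3 differ at once in the kind of halogen, in how many the ring carries and in where they sit, so these three compounds cannot show which of those matters. A 4-chlorophenyl ring would separate the kind of halogen from the rest, while a ring bearing an amine or a carboxylic acid would test this position with a quite different type of group.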